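Same Halogen Swap on a Second Core

The source may hold more compounds than are shown below. What is called first, only, known or untested is meant among the compounds shown, and "the series" means these compounds.

Of the compounds shown here, three have so far been tested in an ADME assay on RAW264.7 cells (Mus musculus) for cytotoxicity, read by MTT assay, with a stated time of 24 h; a lower number here means that less compound is tolerated, a higher number that more compound is tolerated. Compound 1 `O=c1oc2ccc(Br)cc2c(=O)n1-c1ccc(I)cc1F` gives 7900 nM there. Compound 2 `O=c1oc2ccc(Br)cc2c(=O)n1-c1ccc(Cl)cc1F` shares the core of compound 1, and in this assay compound 2 gives 7500 nM. Compound 3 `O=C(Nc1ccc(Cl)cc1F)c1cc(I)ccc1O` is built on a different core; how the core of compound 3 differs from the core of compound 2 is not broken down here. In this assay compound 3 gives 8500 nM. Compound 3 stands nearest to compound 1 and furthest from compound 2, and both of those gaps lie within the usual scatter of this kind of measurement, so the three numbers cannot be ranked against one another.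

Within the data shown here, the one change that has been measured is iodo in place of chloro on an aromatic carbon. It produced a 1.1-fold higher number from compound 2 to compound 1 (0.02 log units; within the scatter), a step that says the two compounds are, for practical purposes, tolerated alike.

Compound 4 `O=C(Nc1ccc(I)cc1F)c1cc(I)ccc1O` has not yet been measured. It arises from compound 3 by iodo in place of chloro on an aromatic carbon, the same change on the same kind of position, now applied to the other core. Resting only on how compound 2 and compound 1 behaved, the step from compound 3 to compound 4 is expected to be a 1.1-fold higher number from compound 3 to compound 4 (0.02 log units; within the scatter), again within the scatter. For compound 4 the expected value in this assay is therefore 9000 nM, with a likely range from 4500 nM to 18000 nM, given that compound 3 sits at 8500 nM and the earlier step was small.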

Compound 4, half-maximal cytotoxic concentration: 6000 nM
Estimate against measurement, compound 4: 1.5-fold (0.18 log units) above, and the stated range covers the measured number.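

In this assay, putting iodo in place of chloro on the second core gives a 1.4-fold lower number from compound 3 to compound 4 (0.15 log units; within the scatter), a step too small to be told apart from the ordinary spread of repeated measurements. Set beside the same change on the first core, this step gives no sign that the core alters what the change does: the same change on two cores in this assay, a 1.1-fold higher number (0.02 log units; within the scatter) from compound 2 to compound 1 and a 1.4-fold lower number (0.15 log units; within the scatter) from compound 3 to compound 4, 1.5-fold (0.17 log units) apart, within the scatter of two such steps. This shows that, for these two pairs, the swap from chloro to iodo left no readable mark on how well the compounds are tolerated on either core, and that the earlier result carried over in that limited sense; it does not show that the change has no effect at all, since a small real effect could hide inside the scatter, and the opposite directions of the two steps carry no meaning, and two pairs cannot establish a rule for the whole series.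

The compounds shown leave open whether a group of a different kind in that place, such as an amine or a carboxylic acid, would shift the number clearly on either core. They also leave open whether such a shift, if it appeared, would be the same size on both cores.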